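Trimming the butyl chain of compound 2 to propyl

The source may hold more compounds than are shown below. What is called first, only, known or untested is meant among the compounds shown, and "the series" means these compounds.

In a functional assay on MiaPaCa cells (Homo sapiens) for antiproliferative activity, read by sulforhodamine B assay, with a stated time of 48 h (on this read-out lower numbers stand for stronger inhibition of growth and higher numbers for weaker inhibition of growth), compound 1 `Cc1ccc(-c2cn(CCCN3C(=O)COc4ccccc43)nn2)cc1` gives > 100000 nM, which is a limit of the assay and not a number. Among the compounds with values here, compound 2 `CCCCc1cn(CCCN2C(=O)COc3ccccc32)nn1`, with butyl in place of 4-methylphenyl, gives 2500 nM, the only true number so far. Compound 3 `CCCc1cn(CCCN2C(=O)COc3ccccc32)nn1` shortens that butyl to propyl, with hydrogen in place of methyl on a saturated chain carbon, three bonds along the chain from an aromatic carbon. Within the data shown here, the only measured step bearing on this is an at least 40-fold lower number from compound 1 to compound 2 (1.60 log units; beyond the scatter), which starts from the limit of > 100000 nM in this assay, at which 1 of the 2 values shown sits, and exchanges a whole group, so it sets no size for so small a change. The expected step is a 1.4-fold higher number from compound 2 to compound 3 (0.15 log units; within the scatter), a slightly higher number that stays within the scatter. For compound 3 the estimated value is 3500 nM, with an expected range of 1200 nM to 10000 nM.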

Compound 3, concentration for 50% growth inhibition: 2600 nM
The estimate for compound 3 lay 1.3-fold (0.13 log units) above the measured number; measured number inside the range.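

In this assay, the change from butyl to propyl gives a 1.0-fold higher number from compound 2 to compound 3 (0.02 log units; within the scatter), so at this place, three bonds along the chain from an aromatic carbon, the two chains cannot be told apart. The large step seen with butyl is not confined to that one chain, as propyl in place of 4-methylphenyl gives an at least 38-fold lower number from compound 1 to compound 3 (1.58 log units; beyond the scatter). The value of compound 1 is a limit of the assay and not a number, so this step does not fix an exact size: the limit of > 100000 nM in this assay, at which 1 of the 3 values shown sits.

The compounds shown leave open whether an ethyl or methyl group on the aromatic carbon, or a longer chain such as hexyl, would stay at this level. They also leave open what a chain ending in an amine or a carboxylic acid would do, and how a cyclohexyl group there would compare with 4-methylphenyl.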